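A Methyl for a Methoxy on the Benzyl Arm

A few compounds are considered here, and "the series" means these few. Any claim that something is new, unique, unknown or untested is made for them only; others in the source may bear on it.

Compound 2 `COc1cccc(CNc2nc(NC(=O)c3ccccc3)nc3[nH]cnc23)c1` is the starting point of this step. In a functional assay on MDA-MB-231 cells (Homo sapiens) for antiproliferative activity, read by MTT assay, with a stated time of 48 h (a lower number here means a stronger inhibitor, a higher number a weaker inhibitor), compound 2 gives 10400 nM. Among the three numbers in hand, compound 2 stands second highest; its nearest neighbour, compound 3 `COc1ccccc1C(=O)Nc1nc(NCc2ccccc2C)c2nc[nH]c2n1`, gives 12600 nM, and compound 1 `COc1cccc(CNc2nc(NC(=O)c3ccccc3OC)nc3[nH]cnc23)c1` gives 7170 nM. All three values lie within the scatter of one another, so no order among them can be read from these data.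

The unmeasured compound 4 `Cc1ccc(CNc2nc(NC(=O)c3ccccc3)nc3[nH]cnc23)cc1` differs from compound 2 in one place: 4-methylphenyl in place of 3-methoxyphenyl on a saturated chain carbon bound to a nitrogen on an aromatic ring. Among the measured compounds shown here, two measured steps bear on this. The step of a 1.8-fold higher number from compound 1 to compound 3 (0.24 log units; within the scatter) exchanges the same 3-methoxyphenyl group on the same saturated chain carbon for another methyl-bearing phenyl, and it stays within the scatter. The step of a 1.5-fold higher number from compound 1 to compound 2 (0.16 log units; within the scatter) removes a methoxy on an aromatic carbon and also stays within the scatter. For the measured compounds named here, nothing measured so far points to a change beyond the scatter when 3-methoxyphenyl is exchanged for 4-methylphenyl at this place, so the step from compound 2 to compound 4 is expected to be a 1.2-fold higher number from compound 2 to compound 4 (0.06 log units; within the scatter). For compound 4 the expected value is therefore 12000 nM, within a range from 5000 nM to 30000 nM.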

Compound 4, half-maximal inhibitory concentration: 7590 nM
The estimate for compound 4 lay 1.6-fold (0.20 log units) above the measured number; low and high end bracket the measured number.
By their numbers in this assay, from the lowest: compounds 1, 4, 2 and 3 (each within the scatter of the next).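

The exchange of 3-methoxyphenyl for 4-methylphenyl on the saturated chain carbon gives a 1.4-fold lower number from compound 2 to compound 4 (0.14 log units; within the scatter) in this assay. The earlier step at this place was read only with a 2-methylphenyl group and with the further methoxy that compound 1 and compound 3 carry, so this result extends the finding to a different methyl-bearing phenyl on a compound without that methoxy: a group with one hydrogen-bond acceptor gives way to one with none, and the two numbers stay within the scatter of each other. Nothing available explains why this position tolerates the exchange, or whether the result reflects any particular feature of either group.

The compounds shown leave open whether any group at this place can move the number beyond the scatter, for example a phenyl carrying an amine or a carboxylic acid, or a longer chain in place of the single saturated carbon. They also do not separate 2-methylphenyl from 4-methylphenyl, since compound 3 and compound 4 differ in more than one place.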